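Methylsulfonyl for Trifluoromethyl: Expected Clearance Shift

The source may hold more compounds than are shown below. What is called first, only, known or untested is meant among the compounds shown, and "the series" means these compounds.

Among the measured compounds shown here, compound 2 `Fc1ccccc1Cc1nc(-c2nc(C(F)(F)F)n[nH]2)n2ccccc12` gives the only numerical value here: in an in vitro ADME assay on microsomes from liver (Homo sapiens) for metabolic stability (on this read-out lower numbers stand for slow clearance and higher numbers for fast clearance), compound 2 gives 72 mL.min-1.g-1. Compound 1 `NC(=O)c1n[nH]c(-c2nc(Cc3ccccc3F)c3ccccn23)n1` reports only a limit, < 8 mL.min-1.g-1, in this assay. For the measured compounds named here, the single measured step, an at least 9.0-fold higher number from compound 1 to compound 2 (0.95 log units; beyond the scatter), bears on the change to compound 3 `CS(=O)(=O)c1n[nH]c(-c2nc(Cc3ccccc3F)c3ccccn23)n1`, which carries methylsulfonyl in place of trifluoromethyl on an aromatic carbon. Because compound 1 sits at the limit of < 8 mL.min-1.g-1 in this assay, at which 1 of the 2 values shown sits, that step is only a lower bound on its true size. A group with 2 hydrogen-bond acceptors now replaces trifluoromethyl, and a drop in clearance is therefore expected for compound 3, a 4.8-fold lower number from compound 2 to compound 3 (0.68 log units; beyond the scatter). Compound 3 is estimated at 15 mL.min-1.g-1, within 6 mL.min-1.g-1 to 40 mL.min-1.g-1.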

Compound 3, intrinsic clearance in microsomes: 11 mL.min-1.g-1
Compound 3: middle estimate off by 1.4-fold (0.13 log units), on the high side; the measured number falls inside the stated range.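

Trifluoromethyl is no longer the only group with a fully measured step at this position: in this assay, methylsulfonyl on this aromatic carbon, between two ring nitrogen atoms, gives a 6.5-fold lower number from compound 2 to compound 3 (0.82 log units; beyond the scatter), a step with a real size rather than a lower bound. Set against carbamoyl, methylsulfonyl gives an at least 1.3-fold higher number from compound 1 to compound 3 (0.13 log units; that floor lies within the scatter), so no order between these two groups can be stated. Compound 1 gives only a limit, and that comparison stays a floor: the limit of < 8 mL.min-1.g-1 in this assay, at which 1 of the 3 values shown sits.

The compounds shown leave open whether an amine or a carboxylic acid on this aromatic carbon would read nearer to compound 2 or to compound 3.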